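Naphthalenyl for methoxyphenyl on a second core

The source may hold more compounds than are shown below. What is called first, only, known or untested is meant among the compounds shown, and "the series" means these compounds.

Measured so far:
Compound 1 `COc1ccc(/C=C2\S/C(=N\c3csc(-c4ccc(Cl)cc4)c3)NC2=O)cc1`: 3800 nM
Compound 2 `O=C1N/C(=N/c2csc(-c3ccc(Cl)cc3)c2)S/C1=C\c1ccc2ccccc2c1`: 3700 nM
Compound 3 `COc1ccc(/C=C2\S/C(=N\c3nc(-c4ccc(Cl)cc4)cs3)NC2=O)cc1`: 400 nM

These values come from a functional assay on HT-29 cells (Homo sapiens) for cytotoxicity, read by MTT assay, with a stated time of 72 h; a lower number here means a stronger inhibitor, a higher number a weaker inhibitor. Compounds 1 and 2 share a core and differ by one change, (naphthalen-2-yl in place of 4-methoxyphenyl on a double-bonded chain carbon bound to a double-bonded ring carbon), and this change gave a 1.0-fold lower number from compound 1 to compound 2 (0.01 log units; within the scatter). Compound 3 sits on a different core; the difference between the two cores is not broken down here. In this assay compound 3 gives the lowest number of the three and is the strongest inhibitor among them.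

Compound 4 `O=C1N/C(=N/c2nc(-c3ccc(Cl)cc3)cs2)S/C1=C\c1ccc2ccccc2c1` has not been measured. It carries the same change on the core of compound 3: naphthalen-2-yl in place of 4-methoxyphenyl on a double-bonded chain carbon bound to a double-bonded ring carbon. Because the same change gave a 1.0-fold lower number from compound 1 to compound 2 (0.01 log units; within the scatter), the expected step is no change at the digits printed from compound 3 to compound 4 (within the scatter). Compound 4 is therefore estimated at 400 nM, between 200 nM and 800 nM.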

Compound 4, half-maximal inhibitory concentration: 1800 nM
For compound 4 the middle estimate is 4.5-fold (0.65 log units) below the measured one; measured number outside the range, above it.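

In this assay, the change weakens compound 4 on the second core, with a 4.5-fold higher number from compound 3 to compound 4 (0.65 log units; beyond the scatter). Naphthalen-2-yl in place of 4-methoxyphenyl therefore did not carry over unchanged from one core to the other: the same change on two cores in this assay, a 1.0-fold lower number (0.01 log units; within the scatter) from compound 1 to compound 2 and a 4.5-fold higher number (0.65 log units; beyond the scatter) from compound 3 to compound 4, 4.6-fold (0.66 log units) apart, beyond the scatter of two such steps. This shows that, in these two pairs, a step read on one core is a poor guide to the same step on the other, but it does not show why the cores differ or which result is more typical of the series.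

The compounds shown leave open how a group such as an amine or a carboxylic acid, placed on the double-bonded chain carbon, would behave on each core. They also leave open whether such groups would separate the two cores in the same way.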